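A Benzyl Group Replaces the 5-Chloro-2-methylphenyl Group

This account rests on a few compounds, and the source may have more. Where it says the series, first, only, none or still open, it means among the compounds named here.

Among the compounds with values here, compound 2 `Cc1ccc(Cl)cc1Nc1nc(C(F)(F)F)ccc1CNC(=O)C(C)c1ccc(NS(C)(=O)=O)c(F)c1` is one of two compounds measured in a functional assay on CHO-K1 cells for antagonist activity at transient receptor potential cation channel subfamily V member 1 (Homo sapiens), read by FLIPR (a higher number here means a weaker inhibitor, a lower number a stronger inhibitor), and in that assay compound 2 gives 14 nM. Its only companion, compound 1 `CC(C(=O)NCc1ccc(C(F)(F)F)nc1NC1CCCCC1)c1ccc(NS(C)(=O)=O)c(F)c1`, carries a cyclohexyl group on the nitrogen on the aromatic ring, and in this assay compound 1 gives 20.4 nM. The step of a 1.5-fold lower number from compound 1 to compound 2 (0.16 log units; within the scatter) is within the scatter, so the two values cannot be placed in order. Compound 3 `CC(C(=O)NCc1ccc(C(F)(F)F)nc1NCc1ccccc1)c1ccc(NS(C)(=O)=O)c(F)c1` has not yet been measured. It differs from compound 2 in one place: benzyl in place of 5-chloro-2-methylphenyl on a nitrogen on an aromatic ring. Within the data shown here, only the step from compound 1 to compound 2 bears on this change, and it was small, showing that the nitrogen on the aromatic ring tolerates either a cyclohexyl or a 5-chloro-2-methylphenyl group without a shift beyond the scatter. On that basis the benzyl group is expected to be tolerated as well, and the step of a 1.8-fold higher number from compound 2 to compound 3 (0.25 log units; within the scatter) is expected to stay within the scatter. For compound 3 in this assay the estimate is 25 nM, with a range from 8 nM to 80 nM.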

Compound 3, inhibition constant: 15.8 nM
The estimate for compound 3 lay 1.6-fold (0.20 log units) above the measured number; low and high end bracket the measured number.
By their numbers in this assay, from the lowest: compounds 2, 3 and 1 (each within the scatter of the next).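

In this assay, benzyl in place of 5-chloro-2-methylphenyl on the nitrogen on an aromatic ring gives a 1.1-fold higher number from compound 2 to compound 3 (0.05 log units; within the scatter), and benzyl in place of cyclohexyl gives a 1.3-fold lower number from compound 1 to compound 3 (0.11 log units; within the scatter), so all three groups now stand within the scatter of one another at this position. The earlier pair set only cyclohexyl against 5-chloro-2-methylphenyl, whereas this exchange keeps a six-membered aromatic ring of carbon only, gives up the chlorine, and still leaves the number within the scatter, which extends the tolerance seen at this nitrogen to a third group and leaves none of the three ranked above another. Nothing available explains why these three groups read alike.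

Cyclohexyl, benzyl and 5-chloro-2-methylphenyl leave open what a longer chain such as 2-phenylethyl, or a group carrying an amine or a carboxylic acid, would give on this nitrogen. From the compounds shown here alone, all three compounds also share one core, and whether the same tolerance holds on any other core remains open.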